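The source may hold more compounds than are shown below. What is called first, only, known or untested is meant among the compounds shown, and "the series" means these compounds.

Three compounds share one core, a cinnamoyl-type chain that ends in a benzimidazole and carries an amide on the other phenyl ring. Compound 1 `O=C(Nc1cccc(/C=C/C(=O)c2nc3ccccc3[nH]2)c1)c1ccccc1` bears a plain benzoyl group and in a functional assay on MCF7 cells (Homo sapiens) for antiproliferative activity, read by MTT assay, with a stated time of 48 h (on this read-out lower numbers stand for stronger inhibition and higher numbers for weaker inhibition), compound 1 gives 11200 nM. Compound 2 `O=C(Nc1cccc(/C=C/C(=O)c2nc3ccccc3[nH]2)c1)c1cccc(Cl)c1` gives 7840 nM, and compound 3 `O=C(Nc1cccc(/C=C/C(=O)c2nc3ccccc3[nH]2)c1)c1ccc(Cl)cc1` gives 8410 nM. Among these three numbers compound 3 stands in the middle; the step of a 1.3-fold lower number from compound 1 to compound 3 (0.12 log units; within the scatter) and the step of a 1.1-fold higher number from compound 2 to compound 3 (0.03 log units; within the scatter) are both within the scatter, and the same holds for a 1.4-fold lower number from compound 1 to compound 2 (0.15 log units; within the scatter). Compound 4 `O=C(Nc1cccc(/C=C/C(=O)c2nc3ccccc3[nH]2)c1)c1cccc(Br)c1` has not been measured. It differs from compound 3 by 3-bromophenyl in place of 4-chlorophenyl on a carbonyl carbon. The step that bears on this most directly is a 1.1-fold higher number from compound 2 to compound 3 (0.03 log units; within the scatter), which moved the position of a halogen without a change beyond the scatter, and the two chloro additions were equally small. The expected step of a 1.1-fold lower number from compound 3 to compound 4 (0.03 log units; within the scatter) in this assay is therefore estimated to stay within the scatter. Compound 4 is expected to give about 7800 nM, in a range from 3900 nM to 15600 nM.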

Compound 4, half-maximal inhibitory concentration: 5210 nM
For compound 4 the middle estimate is 1.5-fold (0.18 log units) above the measured one; the range from low to high includes it.
By their numbers in this assay, from the lowest: compounds 4, 2, 3 and 1 (each within the scatter of the next, the first and the last beyond it).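

In this assay, among these compounds, 3-bromophenyl on the carbonyl carbon gives the first step in this set that lies beyond the scatter (a 2.1-fold lower number from compound 1 to compound 4 (0.33 log units; beyond the scatter)), so a halogen on this ring can now be told apart from hydrogen, though only modestly. Against the two chloro compounds no such separation appears: a 1.5-fold lower number from compound 2 to compound 4 (0.18 log units; within the scatter) and a 1.6-fold lower number from compound 3 to compound 4 (0.21 log units; within the scatter) both stay within the scatter, so compound 4 cannot be ranked against compound 2 or compound 3. The ring attached to the carbonyl therefore accepts chloro and bromo alike in this assay, and only the comparison with the plain benzoyl group of compound 1 shows a difference.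

On these data alone, whether an amine, a carboxylic acid or a methoxy group on this ring would shift the number further, and whether 4-bromophenyl would match 3-bromophenyl, remains open. Nothing available here explains the step.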